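Removing the Phenyl Group From a Weakly Cytotoxic Amidine

This account rests on a few compounds, and the source may have more. Where it says the series, first, only, none or still open, it means among the compounds named here.

In a functional assay on PC-3 cells (Homo sapiens) for cytotoxicity, read by MTT assay, with a stated time of 72 h (on this read-out higher numbers stand for weaker inhibition and lower numbers for stronger inhibition), compound 1 `N=C(Nc1cccc(C(F)(F)F)c1)c1cc2c(-c3ccccc3)n[nH]c2cn1` gives 19900 nM. Compound 2 `Cn1nc(-c2ccccc2)c2cc(C(=N)Nc3cccc(C(F)(F)F)c3)ncc21` gives 20900 nM, the change from compound 1 being a 1.1-fold higher number from compound 1 to compound 2 (0.02 log units; within the scatter). Compound 3 `COc1ccc(Cn2nc(-c3ccccc3)c3cc(C(=N)Nc4cccc(C(F)(F)F)c4)ncc32)cc1` reaches only a limit of this assay, > 50000 nM, as recorded in the limit of > 50000 nM in this assay, at which 1 of the 3 values shown sits. The steps of an at least 2.5-fold higher number from compound 1 to compound 3 (0.40 log units; beyond the scatter) and an at least 2.3-fold higher number from compound 2 to compound 3 (0.37 log units; beyond the scatter) place compound 3 at the weak end of the three values shown. Compound 4 `COc1ccc(Cn2ncc3cc(C(=N)Nc4cccc(C(F)(F)F)c4)ncc32)cc1` differs from compound 3 by hydrogen in place of phenyl on an aromatic carbon. All three measured steps concern the substituent on the aromatic nitrogen, so none bears directly on this change. Compound 3 already sits at the limit, and compound 4 is expected to remain there or weaken further, an estimated step that the limit leaves unreadable from compound 3 to compound 4. Compound 4 is therefore estimated at 80000 nM, within 30000 nM to 300000 nM.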

Compound 4, half-maximal inhibitory concentration: 27600 nM
Compound 4: middle estimate off by 2.9-fold (0.46 log units), on the high side, outside the stated range (below it).
By their numbers in this assay, from the lowest: compounds 1, 2 and 4 (each within the scatter of the next). At a limit, above all of these: compound 3.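

In this assay, hydrogen in place of phenyl on the aromatic carbon gives a readable number where the 4-methoxybenzyl series had stood at a limit, an at least 1.8-fold lower number from compound 3 to compound 4 (0.25 log units; that floor lies within the scatter). The phenyl is therefore not needed for a readable value when 4-methoxybenzyl is present, although this floor alone does not separate the two compounds. The true size of the step cannot be read because one of its ends is a limit: the limit of > 50000 nM in this assay, at which 1 of the 4 values shown sits.

On these data alone, what an amine, a methyl or a carboxylic acid would give on this aromatic carbon remains open. So does the effect of removing the phenyl when hydrogen or methyl sits on the aromatic nitrogen.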